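Working notes: compound 3 to compound 4

The source may hold more compounds than are shown below. What is called first, only, known or untested is meant among the compounds shown, and "the series" means these compounds.

In a functional assay on MCF7 cells (Homo sapiens) for antiproliferative activity, read by MTT assay, with a stated time of 72 h (on this read-out higher numbers stand for weaker inhibition and lower numbers for stronger inhibition), compound 1 `O=S(=O)(Oc1ccc(F)cc1)C1CC2OC1C(c1ccc(/C=C/c3cc(O)cc(O)c3)cc1)=C2c1ccc(O)cc1` gives 13100 nM. Compound 2 `O=S(=O)(Oc1ccc(Cl)cc1)C1CC2OC1C(c1ccc(/C=C/c3cc(O)cc(O)c3)cc1)=C2c1ccc(O)cc1` gives 17900 nM, and a 1.4-fold higher number from compound 1 to compound 2 (0.14 log units; within the scatter) stays within the scatter. Compound 3 `Cc1ccccc1OS(=O)(=O)C1CC2OC1C(c1ccc(/C=C/c3cc(O)cc(O)c3)cc1)=C2c1ccc(O)cc1` gives 55800 nM, the highest number of the three and so the weakest inhibition here.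

The next change leads to compound 4 `O=S(=O)(Oc1ccc(-c2ccccc2)cc1)C1CC2OC1C(c1ccc(/C=C/c3cc(O)cc(O)c3)cc1)=C2c1ccc(O)cc1`: 4-phenylphenyl in place of 2-methylphenyl on an oxygen. In words, 4-phenylphenyl stands in place of 2-methylphenyl on an oxygen.

Among the compounds with values here, two measured steps bear on this, a 4.3-fold higher number from compound 1 to compound 3 (0.63 log units; beyond the scatter) and a 3.1-fold higher number from compound 2 to compound 3 (0.49 log units; beyond the scatter), both modest and beyond the scatter. Read in reverse, they suggest a move away from 2-methylphenyl may lower the number. Within the data shown here, the entering 4-phenylphenyl resembles 4-fluorophenyl and 4-chlorophenyl more than 2-methylphenyl by name, but no measured compound carries a second aromatic ring on that oxygen. A modest step to a lower number is therefore expected in this assay, with low confidence.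

The expected step is a 2.3-fold lower number from compound 3 to compound 4 (0.37 log units; beyond the scatter).

The estimate for compound 4 is 24000 nM, with an expected range of 8000 nM to 70000 nM.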

Compound 4, half-maximal inhibitory concentration: 7800 nM
Compound 4: the middle estimate sits 3.1-fold (0.49 log units) above what was measured; the whole stated range lies above it.
By their numbers in this assay, from the lowest: compounds 4, 1 and 2 (each within the scatter of the next, the first and the last beyond it); then compound 3.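

In this assay the aromatic carbon that carried fluoro or chloro also accepts phenyl, and 4-phenylphenyl in place of 2-methylphenyl on the oxygen gives the largest step in the series (a 7.2-fold lower number from compound 3 to compound 4 (0.85 log units; beyond the scatter)). Phenyl in place of chloro also gives a modest gain (a 2.3-fold lower number from compound 2 to compound 4 (0.36 log units; beyond the scatter)), whereas phenyl in place of fluoro stays within the scatter (a 1.7-fold lower number from compound 1 to compound 4 (0.23 log units; within the scatter)), so a second aromatic ring at this place shows no loss against either halogen. No evidence on hand explains these steps.

Going by these compounds, whether a non-aromatic group on that aromatic carbon, such as an amine, a carboxylic acid or a longer alkyl chain, would match phenyl remains open. The compounds shown also do not separate the identity of the substituent from its place on the ring in compound 3.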